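The source may hold more compounds than are shown below. What is called first, only, known or untested is meant among the compounds shown, and "the series" means these compounds.

In an assay on cells for inhibition of ubiquitin carboxyl-terminal hydrolase 8 (Homo sapiens), read by fluorescence, with a stated time of 30 min (on this read-out higher numbers stand for weaker inhibition and lower numbers for stronger inhibition), compound 1 `Cc1n[nH]c(C)c1Oc1c(O)cc(O)c2c(=O)cc(-c3ccc(N4CCCNCC4)cc3)oc12` gives 17600 nM, and compound 2 `COc1c(O)cc(O)c2c(=O)cc(-c3ccc(N4CCCNCC4)cc3)oc12` gives 31600 nM. Going by the values given here, these two compounds share a core and differ at one oxygen on an aromatic ring; the step between them is a 1.8-fold higher number from compound 1 to compound 2 (0.25 log units; within the scatter), so the two numbers cannot be told apart, and compound 2 stands within the scatter of the only other measured compound.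

Compound 3 `COc1c(O)cc(O)c2c(=O)cc(-c3ccc(N4CCN(C)CC4)cc3)oc12` has not yet been measured in this assay. It differs from compound 2 at another part of the molecule: 4-methylpiperazin-1-yl in place of 1,4-diazepan-1-yl on an aromatic carbon. Among the compounds with values here, no measured step concerns this part of the molecule, and the one step that is known, from compound 1 to compound 2, altered a group on an oxygen and stayed within the scatter, so it gives no guide to the direction of the new change. With nothing pointing either way, the expected step is a 1.1-fold higher number from compound 2 to compound 3 (0.04 log units; within the scatter), which lies within the scatter. The estimate for compound 3 is 35000 nM, in a range from 10000 nM to 120000 nM.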

Compound 3, half-maximal inhibitory concentration: 16500 nM
Estimate against measurement, compound 3: 2.1-fold (0.33 log units) above; the range from low to high includes it.
By their numbers in this assay, from the lowest: compounds 3, 1 and 2 (each within the scatter of the next).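

The change from 1,4-diazepan-1-yl to 4-methylpiperazin-1-yl is the first one shown at this aromatic carbon, and in this assay it gives a 1.9-fold lower number from compound 2 to compound 3 (0.28 log units; within the scatter) and so leaves the two numbers impossible to tell apart. The swap turns a seven-membered ring into a six-membered one and takes the count of hydrogen-bond donors in the group from 1 to 0 with the same heavy atoms, yet this single pair shows no measurable difference at this place. No measurement is available that could explain this result or tie it to any one feature of the two groups.

The pair changes ring size and adds a methyl group together, so a plain piperazin-1-yl group without the methyl would be needed to separate the two changes. Going by these compounds, it also stays open whether a different kind of group on this aromatic carbon, such as a morpholine ring or an open-chain dimethylamino group, would move the number beyond the scatter.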